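Adding a Methyl to a Compound at the Assay Limit

A few compounds are considered here, and "the series" means these few. Any claim that something is new, unique, unknown or untested is made for them only; others in the source may bear on it.

- Compound 1 `CN1C(=S)[C@@H](NC(=O)c2n[nH]c(Cc3ccccc3)n2)COc2ncccc21` gives > 10000 nM as a limit
- Compound 2 `CN1C(=S)[C@H](NC(=O)c2n[nH]c(Cc3ccccc3)n2)COc2ncccc21` gives > 10000 nM as a limit

In a functional assay on HT-29 cells (Homo sapiens) for inhibition, read by luminescence and CellTiter-Glo, with a stated time of 10 h (a higher number here means that more compound is needed for the effect, a lower number that less compound is needed), compound 1 stands at > 10000 nM which is a limit of the assay and not a number. Going by the values given here, its only neighbour offers no better footing, since the record shows the limit of > 10000 nM in this assay, at which 2 of the 2 values shown sit, and no measured number at all. That neighbour is defined by the fact that compounds 1 and 2 differ only in the configuration as drawn and nothing else. Among the compounds with values here, the one measured step is a step that the two limits leave unreadable from compound 1 to compound 2 and so it gives no size to carry forward.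

Compound 3 `Cc1ccc2c(n1)OC[C@H](NC(=O)c1n[nH]c(Cc3ccccc3)n1)C(=S)N2C` keeps the core of compound 1 and changes it in one place (methyl in place of hydrogen on an aromatic carbon), with methyl in place of hydrogen on an aromatic carbon next to the ring nitrogen. Within the data shown here, no measured step touches this position, so no size or direction can be drawn from the data. The expected change is therefore none beyond the scatter, and the estimate is a number no higher from compound 1 to compound 3 (the limit leaves the size open) with a further limit reading as the likeliest result. Compound 3 is estimated at 10000 nM (range 3000 nM to 30000 nM) in this assay when it is measured.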

Compound 3, half-maximal effective concentration: 122 nM
Estimate against measurement, compound 3: 82-fold (1.91 log units) above; the measured number lies below the stated range.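

In this assay, the aromatic carbon next to the ring nitrogen turns out to be a place where a very small change can matter: methyl in place of hydrogen gives an at least 81-fold lower number from compound 1 to compound 3 (1.91 log units; beyond the scatter). Compound 1 gives > 10000 nM, which is a limit of the assay and not a number, so the printed step marks only the smallest size the data allow. The step between compound 1 and compound 2 cannot be read, which makes this the first readable change in the set and compound 3 the first compound shown with a measured number rather than a limit: the limit of > 10000 nM in this assay, at which 2 of the 3 values shown sit.

On these data alone, it remains open whether this lower number is particular to methyl or would also appear with another group at the same place, such as ethyl, a chlorine atom or methoxy, and the data give no reason for the size of the step. Also open is whether the configuration at the saturated ring carbon affects the number once the methyl is present, since the one configuration comparison shown has two limits and no measured number on either side.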